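The source may report more compounds than this note shows. Statements on the series, on what has been measured and on what is new or still open speak of the compounds shown alone.

Measured so far in a functional assay on the whole organism for inhibition, with Mus musculus as the target; a higher number here means that more compound is needed for the effect, a lower number that less compound is needed:
- Compound 1 `CCCCNC(=O)Nc1cccc2c1CN(C)CC2c1ccc(C)cc1`: about 15 mg/kg
- Compound 2 `CCNCC(=O)Nc1cccc2c1CN(C)CC2c1ccc(C)cc1`: 5.6 mg/kg

Of these two, compound 2 has the lower number, so less of it is needed for the effect. Going by the values given here, the only measured step is a 2.7-fold lower number from compound 1 to compound 2 (0.43 log units; beyond the scatter), with (ethylamino)methyl in place of butylamino on a carbonyl carbon.

Compound 3 `CCCCNCC(=O)Nc1cccc2c1CN(C)CC2c1ccc(C)cc1` has not yet been measured in this assay. Its difference from compound 2 is ethyl in place of hydrogen on a saturated chain carbon, two bonds along the chain from an amine nitrogen, which turns ethylamino into butylamino. Among the compounds with values here, no measured step shows this change alone. The step of a 2.7-fold lower number from compound 1 to compound 2 (0.43 log units; beyond the scatter) bears on it only in part, since it alters the chain and its link to the carbonyl together. Compound 3 combines the butyl chain of compound 1 with the link found in compound 2, so a number between those of the two compounds seems likely. The expected change is therefore small and towards a higher number, estimated as a 1.5-fold higher number from compound 2 to compound 3 (0.18 log units; within the scatter). With so little data the range is wide. For compound 3 the estimate is 8.5 mg/kg, with an expected range from 3.5 mg/kg to 20 mg/kg.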

Compound 3, dose for half-maximal effect: about 2.5 mg/kg
The estimate for compound 3 lay 3.4-fold (0.53 log units) above the measured number; measured number outside the range, below it.
By their numbers in this assay, from the lowest: compound 3; then compound 2; then compound 1.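

In this assay, ethyl in place of hydrogen on a saturated chain carbon, two bonds along the chain from an amine nitrogen, turns ethylamino into butylamino and gives a 2.2-fold lower number from compound 2 to compound 3 (0.35 log units; beyond the scatter), so the longer chain is accepted at this position and less compound is needed for the effect. With the butyl chain held the same, the change in the link to the carbonyl alone gives a 6.0-fold lower number from compound 1 to compound 3 (0.78 log units; beyond the scatter), which separates that change from the change in chain length that the earlier step carried together. No measurement given here explains why either change lowers the number.

The compounds shown end at the butyl chain, so it remains open whether a longer chain such as hexyl would lower the number further or reverse the direction of the change. Also open, as far as these compounds go, is how this position would respond to a branched chain such as isobutyl, a ring such as cyclohexyl, or a second alkyl group on the amine nitrogen.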